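This account rests on a few compounds, and the source may have more. Where it says the series, first, only, none or still open, it means among the compounds named here.

Compound 1, `C=CC(=O)N1CCN(Cc2ccc(Nc3nccc(Oc4c(C)cc(/C=C/C#N)cc4C)n3)cc2)CC1`: 5210 nM
Compound 2, `Cc1cc(C#N)cc(C)c1Oc1ccnc(Nc2ccc(CN3CCN(S(=O)(=O)C4CC4)CC3)cc2)n1`: 4430 nM
Compound 3, `Cc1cc(/C=C/C#N)cc(C)c1Oc1ccnc(Nc2ccc(CN3CCCN(S(=O)(=O)C(C)C)CC3)cc2)n1`: 4640 nM

All three compounds were tested in an ADME assay on MT4 cells (Homo sapiens) for cytotoxicity, read by MTT assay; on this read-out lower numbers stand for higher toxicity in this test and higher numbers for lower toxicity in this test. Compound 3 gives 4640 nM, the second highest of the three numbers. The closest of the others is compound 2 with 4430 nM, and the furthest is compound 1 with 5210 nM; both of these lie within the usual scatter of the number for compound 3, so the three compounds cannot be told apart in this assay, and none of them can be called more or less toxic than another.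

Compound 4, `Cc1cc(/C=C/C#N)cc(C)c1Oc1ccnc(Nc2ccc(CN3CCCN(S(=O)(=O)N(C)C)CC3)cc2)n1`, differs from compound 3 in a single place: dimethylamino in place of isopropyl on a sulfonyl sulfur. Within the data shown here, no pair of measured compounds shows a change of this kind, so there is no measured step to lean on. What the data do show is that three compounds differing in several places all give numbers within the scatter of one another in this assay. On that basis the step from compound 3 to compound 4 is expected to be small: a 1.0-fold lower number from compound 3 to compound 4 (0.00 log units; within the scatter), that is, nothing beyond the scatter in either direction. Compound 4 is therefore expected to give about 4600 nM, with a likely range from 2300 nM to 9200 nM.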

Compound 4, half-maximal cytotoxic concentration: 3900 nM
Compound 4: middle estimate off by 1.2-fold (0.07 log units), on the high side; low and high end bracket the measured number.
By their numbers in this assay, from the lowest: compounds 4, 2, 3 and 1 (each within the scatter of the next).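

In this assay, among these compounds, dimethylamino in place of isopropyl on a sulfonyl sulfur gives a 1.2-fold lower number from compound 3 to compound 4 (0.08 log units; within the scatter) and this is the first measured step at this position. The earlier compounds shown here differed in several places at once, whereas this pair isolates the change from isopropylsulfonyl to dimethylsulfamoyl and shows that it stays inside the usual scatter, so neither compound can be called more or less toxic in this test. Nothing at hand bears on why the number stays put.

From the compounds shown here alone, whether a longer chain, a phenyl ring or a carboxylic acid on the sulfonyl sulfur would carry the number beyond the scatter remains open. A single step also cannot tell whether the same change would stay as small in a compound that differs elsewhere, such as compound 2.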